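This account rests on a few compounds, and the source may have more. Where it says the series, first, only, none or still open, it means among the compounds named here.

Measured so far in an ADME assay on HEL cells (Homo sapiens) for cytotoxicity; a lower number here means that less compound is tolerated, a higher number that more compound is tolerated:

compound 1 `COc1ccc(/C=N/NC(=O)COc2cccc3ccccc23)cc1O` — 100 ug/mL
compound 2 `O=C(COc1cccc2ccccc12)N/N=C/C=C/c1ccccc1` — 100 ug/mL
compound 3 `C/C(=N\NC(=O)COc1cccc2ccccc12)c1ccc([N+](=O)[O-])cc1` — 100 ug/mL

Compound 1, compound 2 and compound 3 share the same core, and all three were tested in this assay. Compound 2 stands level with compound 1 and compound 3 at the digits shown: its nearest neighbour in value is compound 1, with no change at the digits shown, and its furthest is compound 3, also with no change at the digits shown. All three values lie within the usual scatter of one another, so no order among them can be read from these numbers.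

The next compound, compound 4 `O=C(COc1cccc2ccccc12)N/N=C/c1cccc(Cl)c1`, has not yet been tested. It differs from compound 2 in one place:

3-chlorophenyl in place of 2-phenylethenyl on a carbon with a double bond to nitrogen

Among the measured compounds shown here, no measured pair here shows what such a change does. Since compound 1, compound 2 and compound 3 all sit at the same value despite carrying different groups at that carbon, the step from compound 2 to compound 4 is expected to stay within the scatter, no change at the digits printed from compound 2 to compound 4 (within the scatter), with no direction favoured. Compound 4 is therefore expected to give about 100 ug/mL in this assay, most likely between 50 ug/mL and 200 ug/mL.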

Compound 4, minimum cytotoxic concentration: 100 ug/mL
Compound 4: the middle estimate sits on the measured number at the digits printed, within the range that was stated.
By their numbers in this assay, from the lowest: compounds 1, 2, 3 and 4 (each within the scatter of the next).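

In this assay, putting 3-chlorophenyl in place of 2-phenylethenyl on a carbon with a double bond to nitrogen gives no change at the digits printed from compound 2 to compound 4 (within the scatter). Among the compounds shown here, this is the first comparison at this position in which only one group differs, so the shared value no longer rests on compounds that differ in more than one place. For this pair, losing the double bond outside the aromatic ring and gaining a chlorine leave the read-out unmoved, though no measurement shown explains why.

Each group shown at this carbon carries a six-membered aromatic ring of carbon only, so the effect of an amine, a carboxylic acid or a longer alkyl chain there remains open. With every value level, these compounds also give no sign of which change at this position, if any, would shift the tolerated concentration.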